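Swapping 3-fluorophenyl for 4-fluorophenyl on a saturated ring carbon

A few compounds are considered here, and "the series" means these few. Any claim that something is new, unique, unknown or untested is made for them only; others in the source may bear on it.

In a physicochemical assay for lipophilicity, using the shake flask method, in phosphate buffer, measured as octanol-water partition, with a stated time of 24 h, at pH 7.4 (on this read-out higher numbers stand for higher lipophilicity and lower numbers for lower lipophilicity), compound 1 (`O=S1(=O)CC(c2cccc(F)c2)c2c(C3CC3)nn(-c3ccccc3F)c2O1`) gives 2.86. Compound 2 (`COc1ccc(-c2nn(-c3ccccc3F)c3c2CCS(=O)(=O)O3)cc1`) gives 2.62, and these two values lie within the usual scatter of repeated measurements, so the numbers do not separate them. Compound 3 (`O=S1(=O)CC(c2ccc(F)cc2)c2c(C3CC3)nn(-c3ccccc3F)c2O1`) has the same atoms as compound 1, joined differently: 4-fluorophenyl in place of 3-fluorophenyl on a saturated ring carbon. Going by the values given here, no measured pair of compounds that differ in one place is available as a guide. Taking compound 1 at 2.86 as the starting point, no step beyond the scatter is expected in this assay, and no direction can be favoured with confidence. The estimated change is a number 0.04 log units higher from compound 1 to compound 3 (within the scatter), well within the scatter. For compound 3 the expected value is 2.9, with an estimated range of 2.6 to 3.2.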

Compound 3, partition coefficient: 1.76
Estimate against measurement, compound 3: 1.14 log units above, and the stated range ends above it.
By their numbers in this assay, from the lowest: compound 3; then compounds 2 and 1 (each within the scatter of the next).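

In this assay, putting 4-fluorophenyl in place of 3-fluorophenyl on the saturated ring carbon gives a number 1.10 log units lower from compound 1 to compound 3 (beyond the scatter) and no atom is gained or lost in the change. At this position, then, two groups with identical counts of atoms are not interchangeable on this read-out, something that compound 1 and compound 2 could not show, as they differ in more than one place. Nothing measured here gives a reason for the step.

As far as these compounds go, whether the same swap would produce a step of this size on another core remains open, and so does the value that a plain phenyl group would give on the same carbon. How an amine or a carboxylic acid in place of the fluorophenyl group would read is also unknown from these compounds.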